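From dibromophenyl to difluorophenyl at the assay limit

This account rests on a few compounds, and the source may have more. Where it says the series, first, only, none or still open, it means among the compounds named here.

Measured in a functional assay on ECV-304 cells (Homo sapiens) for cytotoxicity; a lower number here means a stronger inhibitor, a higher number a weaker inhibitor:
- compound 1 `COc1cccc(/C=C2\SC(=S)N(NS(=O)(=O)c3ccccc3)C2=O)c1` gives > 50000 nM (a limit)
- compound 2 `O=C1/C(=C/c2ccc([N+](=O)[O-])cc2)SC(=S)N1NS(=O)(=O)c1ccccc1` gives > 50000 nM (a limit)
- compound 3 `O=C1/C(=C/c2ccc(Br)c(Br)c2)SC(=S)N1NS(=O)(=O)c1ccccc1` gives > 50000 nM (a limit)

Compound 3 thus has no number, only a limit, and the series shows (the limit of > 50000 nM in this assay, at which 3 of the 3 values shown sit). Compound 4 `O=C1/C(=C/c2ccc(F)cc2F)SC(=S)N1NS(=O)(=O)c1ccccc1` differs from compound 3 by one change: 2,4-difluorophenyl in place of 3,4-dibromophenyl on a double-bonded chain carbon bound to a double-bonded ring carbon. Among the measured compounds shown here, three measured steps bear on this place: a step that the two limits leave unreadable from compound 1 to compound 3, a step that the two limits leave unreadable from compound 2 to compound 3 and a step that the two limits leave unreadable from compound 1 to compound 2. None has a readable size, so they give no direction, and no number is expected to emerge in this assay. The expected step is a number no higher from compound 3 to compound 4 (the limit leaves the size open), with no clear change anticipated. For compound 4 the estimated value is 50000 nM, with an expected range from 25000 nM to 100000 nM.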

Compound 4, half-maximal inhibitory concentration: > 50000 nM
Compound 4 ended at the assay's limit; the forecaster's own chance of this, stated with the estimate: 85%; the middle value lies on the limit itself.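

Among the compounds shown here, no step among compound 1, compound 2, compound 3 and compound 4 can be read in this assay, as all four values are limits. The compounds shown leave open whether these four substituted phenyl groups differ at all in this assay.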